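This account rests on a few compounds, and the source may have more. Where it says the series, first, only, none or still open, it means among the compounds named here.

Of the compounds shown here, two built on a shared core have been measured in an assay on L cells for inhibition of Protein-serine O-palmitoleoyltransferase porcupine (Mus musculus), read by reporter gene assay, with a stated time of 24 h; on this read-out lower numbers stand for an effect already at smaller amounts and higher numbers for an effect only at larger amounts of compound. Compound 1 `COc1ccccc1-n1c(SCC(=O)Nc2nc3ccc(C(F)(F)F)cc3s2)nc2c(c1=O)SCC2` gives 30 nM, while compound 2 `COc1ccc(-n2c(SCC(=O)Nc3nc4ccc(OC)cc4s3)nc3c(c2=O)SCC3)cc1` gives 120 nM. Of these two numbers, compound 2 holds the higher one, and its gap to compound 1 lies beyond the usual scatter; the pair is not a single-change comparison, so that gap cannot be tied to one structural feature. Compound 3 `COc1ccc2nc(NC(=O)CSc3nc4c(c(=O)n3-c3ccccc3OC)SCC4)sc2c1` has not yet been measured. It differs from compound 2 in one respect: 2-methoxyphenyl in place of 4-methoxyphenyl on an aromatic nitrogen. Compound 1 also carries 2-methoxyphenyl on that nitrogen, and compound 1 with its 30 nM sits lower than compound 2, so a move toward a lower number is expected for compound 3, probably of a size that just passes the scatter. The expected step is a 2.4-fold lower number from compound 2 to compound 3 (0.38 log units; beyond the scatter). Compound 3 is therefore estimated at about 50 nM, within a range from 15 nM to 180 nM.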

Compound 3, half-maximal effective concentration: 50 nM
For compound 3 middle estimate and measured number coincide at the digits printed, within the range that was stated.
By their numbers in this assay, from the lowest: compounds 1 and 3 (each within the scatter of the next); then compound 2.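

In this assay, swapping 4-methoxyphenyl for 2-methoxyphenyl on the aromatic nitrogen gives a 2.4-fold lower number from compound 2 to compound 3 (0.38 log units; beyond the scatter), a modest step. This first single-change comparison at this position shows that the number responds to where the methoxy sits on the phenyl ring, even though the two groups hold the same atoms. The other change, methoxy in place of trifluoromethyl on an aromatic carbon, gives a 1.7-fold higher number from compound 1 to compound 3 (0.22 log units; within the scatter), which lies within the scatter, so these two groups cannot be told apart here. Nothing measured on these compounds accounts for either step.

For the compounds shown here, only two methoxyphenyl groups have been compared at the aromatic nitrogen, so it remains open how a plain phenyl, a 2-ethoxyphenyl or a 2-chlorophenyl would read there. On these data alone, it is also open whether the step at this nitrogen would recur with trifluoromethyl in place of methoxy on the aromatic carbon.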